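Swapping an iodophenyl for an isopropyl on a quinone amidine

The source may report more compounds than this note shows. Statements on the series, on what has been measured and on what is new or still open speak of the compounds shown alone.

Measured compounds:
- compound 1, `Cc1ccc(S(=O)(=O)/N=C(/CCNC2=CC(=O)c3ccccc3C2=O)Nc2ccccc2I)cc1`: 49400 nM
- compound 2, `Cc1ccc(S(=O)(=O)/N=C(/CCNC2=CC(=O)c3ccccc3C2=O)Nc2cc(F)c(F)c(F)c2)cc1`: 82600 nM

Both measured compounds were tested in an ADME assay on HEK293 cells (Homo sapiens) for cytotoxicity, read by MTT assay, with a stated time of 48 h; on this read-out higher numbers stand for weaker inhibition and lower numbers for stronger inhibition. In this assay compound 1 gives 49400 nM, and compound 2 gives 82600 nM; the step of a 1.7-fold higher number from compound 1 to compound 2 (0.22 log units; within the scatter) shows the two values lie within the scatter of each other, so neither can be called the stronger or weaker.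

Compound 3, `Cc1ccc(S(=O)(=O)/N=C(/CCNC2=CC(=O)c3ccccc3C2=O)NC(C)C)cc1`, has not yet been measured. It differs from compound 1 in one place: isopropyl in place of 2-iodophenyl on an amine nitrogen. Among the measured compounds shown here, no measured step covers this kind of change; the only step known, a 1.7-fold higher number from compound 1 to compound 2 (0.22 log units; within the scatter), exchanges one aromatic ring for another and lies within the scatter. For the measured compounds named here, with no evidence of movement from the one exchange seen, a step of a 1.2-fold higher number from compound 1 to compound 3 (0.08 log units; within the scatter) is expected, essentially none beyond the scatter. Compound 3 is therefore estimated at 60000 nM, with a range from 25000 nM to 150000 nM.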

Compound 3, half-maximal inhibitory concentration: 71600 nM
The estimate for compound 3 lay 1.2-fold (0.08 log units) below the measured number, and the stated range covers the measured number.
By their numbers in this assay, from the lowest: compounds 1, 3 and 2 (each within the scatter of the next).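

Taking the aromatic ring off this amine nitrogen and putting isopropyl there gives, in this assay, a 1.4-fold higher number from compound 1 to compound 3 (0.16 log units; within the scatter) and a 1.2-fold lower number from compound 2 to compound 3 (0.06 log units; within the scatter) as well. The earlier compounds showed only one aromatic ring exchanged for another, whereas these steps show that a group with no ring and fewer heavy atoms also stays within the scatter of both aromatic compounds, so among these three compounds an aromatic ring at this position makes no readable difference to the number. Nothing available gives a reason for this result.

From the compounds shown here alone, whether a longer alkyl chain on this nitrogen would also stay within the scatter remains open. So does the outcome for a group carrying a carboxylic acid or a further amine at the same place.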